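The compounds below may be only part of what the source reports. "The series", "measured", "known", "first", "only" and "open" are said of these compounds alone.

In an assay on HEK293 cells for negative allosteric modulation of metabotropic glutamate receptor 5 (Homo sapiens), read by FLIPR (a lower number here means a stronger inhibitor, a higher number a weaker inhibitor), compound 1 `Cc1cccc(-c2noc(C3CN(S(=O)(=O)c4cccc(C)c4)C3)n2)c1` gives 650 nM, and compound 3 `Cc1ccc(S(=O)(=O)N2CC(c3nc(-c4cccc(Cl)c4)no3)C2)cc1` gives 920 nM. Compound 2 `O=C(N1CCCCC1)N1CC(c2nc(-c3cccc(Cl)c3)no2)C1` reaches only the limit of this assay, > 10000 nM, so for it a boundary is known rather than a number; this is the limit of > 10000 nM in this assay, at which 1 of the 3 values shown sits. Compound 4 `O=C(N1CCCCCC1)N1CC(c2nc(-c3cccc(Cl)c3)no2)C1` has not yet been measured; it differs from compound 2 by azepan-1-yl in place of piperidin-1-yl on a carbonyl carbon. Among the measured compounds shown here, no measured pair shows how such a change acts in this assay, and compound 2 sits at the limit, so the step that the limit leaves unreadable from compound 2 to compound 4 is expected to be none beyond the scatter, with compound 4 expected to remain close to that boundary. Compound 4 is therefore estimated at about 15000 nM, with a range from 4000 nM to 50000 nM.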

Compound 4, half-maximal inhibitory concentration: > 10000 nM
Compound 4: only a limit was reported (the forecaster's own chance of this, stated with the estimate: 70%); the middle value lies beyond the limit too.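

Compound 2 and compound 4 both stop at a limit of this assay rather than giving a number, so no step can be read between them: the limit of > 10000 nM in this assay, at which 2 of the 4 values shown sit.

From the compounds shown here alone, whether azepan-1-yl in place of piperidin-1-yl on a carbonyl carbon changes inhibition at all remains open.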